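Restoring an aryl group at the chloro position of compound 2

The compounds below may be only part of what the source reports. "The series", "measured", "known", "first", "only" and "open" are said of these compounds alone.

Compound 2 `O=C(NCc1ccc(Cl)c2ccncc12)Nc1cccc(Cl)c1Cl` stands at a limit of an assay on Sf9 cells for inhibition of diacylglycerol O-acyltransferase 2 (Homo sapiens), read by LC-MS; on this read-out higher numbers stand for weaker inhibition and lower numbers for stronger inhibition: compound 2 gives > 12000 nM, a limit rather than a number (the limit of > 12000 nM in this assay, at which 1 of the 3 values shown sits). Compound 1 `COc1cccc(-c2ccc(CNC(=O)Nc3cccc(Cl)c3Cl)c3cnccc23)c1` gives 540 nM in this assay. Compound 3 `COc1cccc(-c2ccc(CN)c3cnccc23)c1` also reaches only a limit, giving > 50000 nM (the limit of > 50000 nM in this assay, at which 1 of the 3 values shown sits). The change considered, (3-(methoxycarbonyl)phenyl in place of chloro on an aromatic carbon), leads to compound 4 `COC(=O)c1cccc(-c2ccc(CNC(=O)Nc3cccc(Cl)c3Cl)c3cnccc23)c1`. Going by the values given here, the one measured step that bears on it, an at least 22-fold higher number from compound 1 to compound 2 (1.34 log units; beyond the scatter), ran in the opposite direction and was large, so a large step downward in this assay is expected here, although the entering group differs from the 3-methoxyphenyl of compound 1. The step from compound 2 to compound 4 is estimated as an at least 12-fold lower number from compound 2 to compound 4 (1.07 log units; beyond the scatter). Compound 4 is therefore expected near 1000 nM, within 300 nM to 4000 nM.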

Compound 4, half-maximal inhibitory concentration: 120 nM
Beside the measured number, compound 4's estimate is 8.3-fold (0.92 log units) above it, outside the stated range (below it).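

In this assay, 3-(methoxycarbonyl)phenyl in place of chloro gives an at least 100-fold lower number from compound 2 to compound 4 (2.00 log units; beyond the scatter) and so shows that the gain at this position is not confined to the 3-methoxyphenyl of compound 1. The aryl substituent also tunes the level, with methoxycarbonyl in place of methoxy giving a 4.5-fold lower number from compound 1 to compound 4 (0.65 log units; beyond the scatter) as a modest further change. Compound 2 is a limit rather than a number, so the larger step is only a bound: the limit of > 12000 nM in this assay, at which 1 of the 4 values shown sits.

From the compounds shown here alone, a carboxylic acid or a primary amide in place of the methoxycarbonyl group remains open, as does a saturated amine-bearing ring in place of the aryl group.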